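Shifting a Methyl Group on the Aryl Ether

This account rests on a few compounds, and the source may have more. Where it says the series, first, only, none or still open, it means among the compounds named here.

Of the compounds shown here, three sharing one core have so far been measured in an assay on HEK293 cells for displacement of a labelled ligand from 5-hydroxytryptamine receptor 7 (Homo sapiens), read by radioligand binding, with a stated time of 1 h; on this read-out lower numbers stand for stronger inhibition and higher numbers for weaker inhibition. Compound 1 `CN1CCN(c2nc(N)nc(COc3ccccc3Cl)n2)CC1` gives 9250 nM, compound 2 `Cc1ccc(C(C)C)c(OCc2nc(N)nc(N3CCN(C)CC3)n2)c1` gives 12000 nM, and compound 3 `Cc1ccccc1OCc1nc(N)nc(N2CCN(C)CC2)n1` gives 514 nM. Within the data shown here, compound 3 thus holds the lowest number of the three: the change from compound 1 to compound 3 brings an 18-fold lower number from compound 1 to compound 3 (1.26 log units; beyond the scatter), and compound 2 stands further still from compound 3, though no single-point step joins those two, as compound 2 also carries an isopropyl group.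

Compound 4 `Cc1cccc(OCc2nc(N)nc(N3CCN(C)CC3)n2)c1` has not yet been measured. It differs from compound 3 in one place: 3-methylphenyl in place of 2-methylphenyl on an oxygen on a saturated carbon. Among the measured compounds shown here, no measured pair shows what happens when the methyl is moved rather than exchanged, so the only step that bears on the question is the large one from compound 1 to compound 3, which shows that what sits on this aryl ring weighs heavily in this assay. Compound 2, whose ring carries both a methyl and an isopropyl, gives the highest number, suggesting the arrangement on the ring is not indifferent. In this assay the expected outcome is therefore a moderate rise, a 3.9-fold higher number from compound 3 to compound 4 (0.59 log units; beyond the scatter). Compound 4 is estimated at 2000 nM, within a range from 500 nM to 8000 nM.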

Compound 4, inhibition constant: 10700 nM
Beside the measured number, compound 4's estimate is 5.4-fold (0.73 log units) below it; measured number outside the range, above it.
By their numbers in this assay, from the lowest: compound 3; then compounds 1, 4 and 2 (each within the scatter of the next).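

In this assay, moving the methyl with no atom gained or lost gives a 21-fold higher number from compound 3 to compound 4 (1.32 log units; beyond the scatter) in a large step, so 3-methylphenyl in place of 2-methylphenyl on this oxygen is enough to remove the advantage of compound 3. The higher number of compound 2 therefore does not depend on its isopropyl group: hydrogen in its place gives a 1.1-fold lower number from compound 2 to compound 4 (0.05 log units; within the scatter) and stays within the scatter. The exchange of 2-chlorophenyl for 3-methylphenyl gives a 1.2-fold higher number from compound 1 to compound 4 (0.06 log units; within the scatter) and is also within the scatter, which leaves compound 3 alone, apart from the other three compounds, with its 2-methylphenyl group.

As far as these compounds go, it remains open whether an ethyl or a methoxy group on the aromatic carbon that carries the methyl of compound 3 would keep a number close to that of compound 3, or whether the methyl itself is required. No evidence is available to explain why the place of the methyl matters so strongly in this series.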